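A few compounds are considered here, and "the series" means these few. Any claim that something is new, unique, unknown or untested is made for them only; others in the source may bear on it.

Measured in a functional assay (mast cells) for inhibition, with Rattus norvegicus as the target; on this read-out lower numbers stand for an effect already at smaller amounts and higher numbers for an effect only at larger amounts of compound:
- compound 1 `CC1CC/C(=N\Nc2ccc(Br)cc2)c2ncc(C(=O)O)c(=O)n21` gives 2000 nM
- compound 2 `CC1CC/C(=N\Nc2ccc(C(=O)O)cc2)c2ncc(C(=O)O)c(=O)n21` gives 1000000 nM
- compound 3 `CC(C)c1ccc(N/N=C2\CCC(C)n3c2ncc(C(=O)O)c3=O)cc1` gives 1200 nM

Compound 3, at 1200 nM, stands within the scatter of compound 1 and far from compound 2, so two of the three values form a group and one sits well apart.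

The next compound is compound 4 `CCCCc1ccc(N/N=C2\CCC(C)n3c2ncc(C(=O)O)c3=O)cc1`, not yet measured. It has butyl in place of isopropyl on an aromatic carbon, para to a large group: butyl in place of isopropyl on an aromatic carbon.

The closest evidence is a 1.7-fold lower number from compound 1 to compound 3 (0.22 log units; within the scatter), a swap at the same carbon that stays within the scatter. The two large steps, a 500-fold higher number from compound 1 to compound 2 (2.70 log units; beyond the scatter) and an 830-fold lower number from compound 2 to compound 3 (2.92 log units; beyond the scatter), both involve carboxy at that carbon, and compound 4 does not carry carboxy there. Within the data shown here, no butyl compound has been measured, and the set holds only three substituents at this carbon, so the expectation rests on thin evidence.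

In this assay, the expected result is no change beyond the scatter, with a small estimated step of a 1.2-fold lower number from compound 3 to compound 4 (0.08 log units; within the scatter).

Compound 4 is estimated at 1000 nM, with an expected range from 350 nM to 3000 nM.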

Compound 4, half-maximal effective concentration: 1700 nM
Estimate against measurement, compound 4: 1.7-fold (0.23 log units) below; the measured number falls inside the stated range.
By their numbers in this assay, from the lowest: compounds 3, 4 and 1 (each within the scatter of the next); then compound 2.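

Working notes on the aromatic carbon para to a large group: in this assay, butyl joins bromo and isopropyl in a single band, with compound 4 within the scatter of both neighbours (a 1.4-fold higher number from compound 3 to compound 4 (0.15 log units; within the scatter)) and (a 1.2-fold lower number from compound 1 to compound 4 (0.07 log units; within the scatter)). Lengthening the substituent from the isopropyl of compound 3 to the butyl of compound 4 therefore gives no readable change in this assay, and the three non-carboxy groups tested here cannot be ranked. Carboxy remains the lone outlier at this carbon, and the gap now holds against a third group (a 590-fold lower number from compound 2 to compound 4 (2.77 log units; beyond the scatter)), although no measurement on hand offers an explanation for this separation.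

Still open, from the compounds shown here alone, is whether the band extends to a longer chain such as hexyl or to other groups at this carbon, such as an amine, a methoxy group or a primary amide, and the last of these would show whether the outlying value is specific to carboxy. All four compounds share the same core, so the contribution of its carboxylic acid and its methyl group cannot be read from this set.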